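Cytotoxicity notes: ethoxycarbonyl for iodo, compound 3 to compound 4

The source may hold more compounds than are shown below. What is called first, only, known or untested is meant among the compounds shown, and "the series" means these compounds.

Of the compounds shown here, three carry a value so far: compound 1 `FC(F)(F)c1cccc(NC(=S)Nc2ccc(Cl)cc2)c1`, compound 2 `CC[C@H]1CC[C@H](c2ccc(NC(=S)Nc3cccc(C(F)(F)F)c3)cc2)CC1` and compound 3 `FC(F)(F)c1cccc(NC(=S)Nc2ccc(I)cc2)c1`, which share one core. In an ADME assay on MDBK cells (Bos taurus) for cytotoxicity, read by MTT assay, with a stated time of 96 h (a lower number here means that less compound is tolerated, a higher number that more compound is tolerated), compound 1 gives 17000 nM, compound 2 gives 9000 nM and compound 3 gives 9500 nM. Compound 3 stands second highest of the three numbers; its nearest neighbour is compound 2, with a 1.1-fold higher number from compound 2 to compound 3 (0.02 log units; within the scatter), and the furthest is compound 1, with a 1.8-fold lower number from compound 1 to compound 3 (0.25 log units; within the scatter). The remaining pair shows a 1.9-fold lower number from compound 1 to compound 2 (0.28 log units; within the scatter). All three separations sit within the scatter, so the three compounds are treated as indistinguishable in this assay.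

Compound 4 `CCOC(=O)c1ccc(NC(=S)Nc2cccc(C(F)(F)F)c2)cc1` is not yet measured. Against compound 3 the change is ethoxycarbonyl in place of iodo on an aromatic carbon. The measured steps that touch the same place are a 1.8-fold lower number from compound 1 to compound 3 (0.25 log units; within the scatter) and a 1.1-fold higher number from compound 2 to compound 3 (0.02 log units; within the scatter), together with a 1.9-fold lower number from compound 1 to compound 2 (0.28 log units; within the scatter); none of them moved the number beyond the scatter, and none introduces an ethoxycarbonyl group, so the bearing is indirect. The expectation for this assay is therefore a step of a 1.3-fold higher number from compound 3 to compound 4 (0.10 log units; within the scatter), not beyond the scatter. Compound 4 is estimated at 12000 nM in this assay, with a range from 4000 nM to 36000 nM.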

Compound 4, half-maximal cytotoxic concentration: 64000 nM
Beside the measured number, compound 4's estimate is 5.3-fold (0.73 log units) below it; measured number above the stated range.
By their numbers in this assay, from the lowest: compounds 2, 3 and 1 (each within the scatter of the next); then compound 4.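

In this assay, among the compounds shown here, the aromatic carbon para to a large group had not separated chloro, iodo and 4-ethylcyclohexyl, whereas ethoxycarbonyl gives the first change beyond the scatter at this place: (a 6.7-fold higher number from compound 3 to compound 4 (0.83 log units; beyond the scatter)), with (a 7.1-fold higher number from compound 2 to compound 4 (0.85 log units; beyond the scatter)) and (a 3.8-fold higher number from compound 1 to compound 4 (0.58 log units; beyond the scatter)) pointing the same way. The position is therefore not indifferent to its substituent, and among the compounds shown the higher number goes with the one group that differs from iodo by a double bond outside aromatic rings and by hydrogen-bond acceptors, though three earlier groups and one new group are too few to make this a trend. No measurement available here accounts for the rise or assigns it to any part of the ethoxycarbonyl group.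

The compounds shown leave open whether the step follows the carbonyl or needs the ethyl chain as well, a question that a carboxylic acid or a methoxycarbonyl group at the same carbon would address. From the compounds shown here alone, all four compounds also keep the trifluoromethyl group, so it remains open whether the step would hold with a nitrile or a methoxy group in its place.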